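The compounds below may be only part of what the source reports. "The series", "measured", "known", "first", "only" and "open" are said of these compounds alone.

Of the compounds shown here, three have been measured. In a functional assay on L1210 cells (Mus musculus) for inhibition (on this read-out lower numbers stand for stronger inhibition and higher numbers for weaker inhibition), compound 1 `Nc1ccn(C/C=C\CCl)c(=O)n1` gives 10000 nM. Compound 2 `Cc1cn(C/C=C\CCl)c(=O)[nH]c1=O` gives 46000 nM in this assay. Compound 3 `Nc1ccn(C/C=C\CO)c(=O)n1` reaches only a limit of this assay, > 1000000 nM.

Compound 1 and compound 3 differ in one place, (hydroxy in place of chloro on a saturated chain carbon bound to a double-bonded chain carbon). That change gave an at least 100-fold higher number from compound 1 to compound 3 (2.00 log units; beyond the scatter), a step that ran up against (the limit of > 1000000 nM in this assay, at which 1 of the 3 values shown sits). Compound 2 carries the same chain as compound 1, but the difference between the two cores is not broken down here; compound 2 stands higher than compound 1 in this assay, beyond the scatter.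

Compound 4 `Cc1cn(C/C=C\CO)c(=O)[nH]c1=O` is not yet measured. It differs from compound 2 by hydroxy in place of chloro on a saturated chain carbon bound to a double-bonded chain carbon, the same change, at the same place, as from compound 1 to compound 3. Compound 4 is therefore expected to show a step of about a 65-fold higher number from compound 2 to compound 4 (1.81 log units; beyond the scatter) from compound 2, resting on an at least 100-fold higher number from compound 1 to compound 3 (2.00 log units; beyond the scatter). Starting from the value of compound 2, compound 4 is estimated at 3000000 nM, between 800000 nM and 20000000 nM, most probably reported only as a limit.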

Compound 4, half-maximal inhibitory concentration: > 1000000 nM
Compound 4 ended at the assay's limit; the forecaster's own chance of this, stated with the estimate: 80%; the middle value does not contradict the limit.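

In this assay, putting hydroxy in place of chloro on a saturated chain carbon bound to a double-bonded chain carbon again sharply weakened inhibition, with an at least 21-fold higher number from compound 2 to compound 4 (1.33 log units; beyond the scatter). The change therefore went the same way on the core of compound 2 as on the core of compound 1, so on these two cores its direction carried over, and the two steps can be set side by side: the same change on two cores in this assay, an at least 100-fold higher number (2.00 log units; beyond the scatter) from compound 1 to compound 3 and an at least 21-fold higher number (1.33 log units; beyond the scatter) from compound 2 to compound 4; the limit leaves it open whether they differ. What this does not show is the true size of either step or whether one core feels the change more, since both hydroxy compounds stop at one limit: the limit of > 1000000 nM in this assay, at which 2 of the 4 values shown sit.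

The compounds shown leave open whether other groups at the same chain end, such as an amine or a carboxylic acid, would keep any of the inhibition seen with chloro. They also leave open whether the same change would act alike on a longer chain.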